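From compound 3 to compound 4: a shorter chain

The source may hold more compounds than are shown below. What is called first, only, known or untested is meant among the compounds shown, and "the series" means these compounds.

In a functional assay on PC-3 cells (Homo sapiens) for antiproliferative activity, read by MTT assay, with a stated time of 72 h (on this read-out lower numbers stand for stronger inhibition and higher numbers for weaker inhibition), compound 3 (`CCCCCCCCCCCCNC[C@@H]1OC[C@H](N)[C@@H]1O`) stands lowest of the three measured, at 850 nM against compound 2 (`CCCCCCCCCNC[C@@H]1OC[C@H](N)[C@H]1O`) at 7650 nM and compound 1 (`CCCCCCCCNC[C@@H]1OC[C@H](N)[C@@H]1O`) at 13800 nM on the same scale. Compound 4 (`CCCCCCCCCNC[C@@H]1OC[C@H](N)[C@@H]1O`) awaits measurement. It differs from compound 3 by hydrogen in place of propyl on a saturated chain carbon, nine bonds along the chain from an amine nitrogen in all, hydrogen in place of propyl on a saturated chain carbon, nine bonds along the chain from an amine nitrogen. Going by the values given here, one measured step bears on this: butyl in place of hydrogen gave a 16-fold lower number from compound 1 to compound 3 (1.21 log units; beyond the scatter) and so a large drop. Here the change runs the other way and removes propyl rather than butyl, so a large but slightly smaller rise is expected in this assay for this change. The estimated change is a 7.6-fold higher number from compound 3 to compound 4 (0.88 log units; beyond the scatter) and it points toward weaker inhibition. For compound 4 the estimate is 6500 nM with an expected range of 3000 nM to 13000 nM in all.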

Compound 4, half-maximal inhibitory concentration: 2030 nM
Compound 4: middle estimate off by 3.2-fold (0.51 log units), on the high side, outside the stated range (below it).
By their numbers in this assay, from the lowest: compound 3; then compound 4; then compounds 2 and 1 (each within the scatter of the next).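

In this assay the chain steps are uneven: removing propyl gives a 2.4-fold higher number from compound 3 to compound 4 (0.38 log units; beyond the scatter) as a modest rise, while adding methyl gives a 6.8-fold lower number from compound 1 to compound 4 (0.83 log units; beyond the scatter) as a modest drop, so much of the gain along this series is already reached at compound 4. A single ring stereocentre also matters, with a 3.8-fold lower number from compound 2 to compound 4 (0.58 log units; beyond the scatter) on going from R to S. That gap can be put down to configuration alone because of one fact: the fact that compounds 2 and 4 differ only in the configuration as drawn.

On these data alone, whether a chain longer than that of compound 3 lowers the number further stays open. So does whether an amide could stand in place of the chain amine.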